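From Hydrogen to Nitro on an Aromatic Carbon

The source may report more compounds than this note shows. Statements on the series, on what has been measured and on what is new or still open speak of the compounds shown alone.

In an ADME assay on Vero cells (Chlorocebus sabaeus) for cytotoxicity, read by crystal violet staining (on this read-out higher numbers stand for lower toxicity in this test and lower numbers for higher toxicity in this test), compound 1 (`c1ccc(/N=N/N2CCCCC2)cc1`) gives > 100000 nM, which is a limit of the assay and not a number. Compound 2 (`Clc1ccc(/N=N/N2CCCCC2)cc1`) gives > 100000 nM, again a limit. For the measured compounds named here, the only measured step is a step that the two limits leave unreadable from compound 1 to compound 2, so it supplies no size to carry forward. All that bears on the next change is the limit of > 100000 nM in this assay, at which 2 of the 2 values shown sit.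

Compound 3 (`O=[N+]([O-])c1cccc(/N=N/N2CCCCC2)c1`) has nitro in place of hydrogen on an aromatic carbon. Going by the values given here, this is a different group from the chloro of compound 2, and no measured step gives its size. No step beyond the scatter, in either direction, is therefore expected in this assay. The expected result is a number no higher from compound 1 to compound 3 (the limit leaves the size open). Compound 3 is estimated at 100000 nM, with an expected range from 40000 nM to 200000 nM.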

Compound 3, half-maximal cytotoxic concentration: 83000 nM
Beside the measured number, compound 3's estimate is 1.2-fold (0.08 log units) above it; the range from low to high includes it.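

Compound 3 is the only compound shown that gives a number rather than a limit in this assay and so puts the first readable value on this series. Nitro in place of hydrogen, meta to a group of 8 heavy atoms, gives an at least 1.2-fold lower number from compound 1 to compound 3 (0.08 log units; that floor lies within the scatter) and that figure is only a floor, so the true size of the step stays unknown. The other two values shown remain limits: the limit of > 100000 nM in this assay, at which 2 of the 3 values shown sit.

Going by these compounds, what an amine or a carboxylic acid on the same aromatic carbon would do stays open. The compounds shown also cannot tell whether the number for compound 3 belongs to the nitro group itself or to its place on the ring.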